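A few compounds are considered here, and "the series" means these few. Any claim that something is new, unique, unknown or untested is made for them only; others in the source may bear on it.

Compound 1, `COc1ccc(C2=NN(C3=NC(c4ccccc4)CS3)C(c3cccc4ccccc34)C2)cc1`, compound 2, `c1ccc(C2=NN(C3=NC(c4ccccc4)CS3)C(c3cccc4ccccc34)C2)cc1`, and compound 3, `COc1ccc(C2=NN(C3=NC(c4ccccc4)CS3)C(c3ccc4ccccc4c3)C2)cc1`, have been tested in a functional assay on HepG2 cells (Homo sapiens) for inhibition, read by CCK-8 assay, with a stated time of 48 h; on this read-out lower numbers stand for stronger inhibition and higher numbers for weaker inhibition. Compound 1 gives 8740 nM in this assay, compound 2 gives 13200 nM, and compound 3 gives 12600 nM. The change hydrogen in place of methoxy on an aromatic carbon produced a 1.5-fold higher number from compound 1 to compound 2 (0.18 log units; within the scatter). The cores of compound 1 and compound 3 differ by naphthalen-2-yl in place of naphthalen-1-yl on a saturated ring carbon, which gave a 1.4-fold higher number from compound 1 to compound 3 (0.16 log units; within the scatter). Compound 4, `c1ccc(C2=NN(C3=NC(c4ccccc4)CS3)C(c3ccc4ccccc4c3)C2)cc1`, has not yet been measured in this assay. It differs from compound 3 by hydrogen in place of methoxy on an aromatic carbon, the same change as that from compound 1 to compound 2, at a place described in the same words. Because a 1.5-fold higher number from compound 1 to compound 2 (0.18 log units; within the scatter) stayed within the scatter, compound 4 is expected to give a number close to that of compound 3, and the step is estimated as a 1.4-fold higher number from compound 3 to compound 4 (0.14 log units; within the scatter) in this assay. Compound 4 is accordingly estimated at 17500 nM, with a likely range from 9000 nM to 35000 nM.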

Compound 4, half-maximal inhibitory concentration: 17200 nM
The estimate for compound 4 lay 1.0-fold (0.01 log units) above the measured number; low and high end bracket the measured number.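

In this assay, the change from 4-methoxyphenyl to phenyl gave a 1.4-fold higher number from compound 3 to compound 4 (0.14 log units; within the scatter), which agrees with the step seen for the same change on the other core: the same change on two cores in this assay, a 1.5-fold higher number (0.18 log units; within the scatter) from compound 1 to compound 2 and a 1.4-fold higher number (0.14 log units; within the scatter) from compound 3 to compound 4, 1.1-fold (0.04 log units) apart, within the scatter of two such steps. The change from naphthalen-1-yl to naphthalen-2-yl gave a 1.3-fold higher number from compound 2 to compound 4 (0.11 log units; within the scatter), and it also carried over between cores: the same change on two cores in this assay, a 1.4-fold higher number (0.16 log units; within the scatter) from compound 1 to compound 3 and a 1.3-fold higher number (0.11 log units; within the scatter) from compound 2 to compound 4, 1.1-fold (0.04 log units) apart, within the scatter of two such steps. Both changes therefore behaved alike on the two cores shown, but every one of these steps lies within the scatter, so the agreement shows only that neither change moved the number measurably on either core, not that either has a real effect that transfers, and two cores cannot establish a rule for the series.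

The compounds shown carry only methoxy or hydrogen at this place on the aromatic ring, so it remains open whether an amine, a carboxylic acid or a longer alkoxy chain there would give a step beyond the scatter. From the compounds shown here alone, whether such a step would then carry from one core to the other is equally open.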